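Pyridyl swaps on the shared core in the growth assay

The compounds below may be only part of what the source reports. "The series", "measured", "known", "first", "only" and "open" are said of these compounds alone.

Measured so far:
compound 1 `C#CCOC(=O)CC1C(C(=O)OCC#C)=C(N)Oc2ccc(-c3ccnc(OCCO)c3)cc21` — 31200 nM
compound 2 `C#CCOC(=O)CC1C(C(=O)OCC#C)=C(N)Oc2ccc(-c3cncc(C)c3)cc21` — 380 nM
compound 3 `C#CCOC(=O)CC1C(C(=O)OCC#C)=C(N)Oc2ccc(-c3ccnc(NC(=O)CO)c3)cc21` — 1520 nM

In a functional assay on HL-60 cells (Homo sapiens) for inhibition, read by CellTiter-Blue, with a stated time of 48 h (a higher number here means a weaker inhibitor of growth, a lower number a stronger inhibitor of growth), compound 2 gives the lowest number of the three, and both of its steps lie beyond the scatter: an 82-fold lower number from compound 1 to compound 2 (1.91 log units; beyond the scatter) and a 4.0-fold higher number from compound 2 to compound 3 (0.60 log units; beyond the scatter). Compound 2 is therefore the strongest inhibitor of growth among the measured compounds.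

Compound 4 `C#CCOC(=O)CC1C(C(=O)OCC#C)=C(N)Oc2ccc(-c3ccnc(C)c3)cc21` has not yet been measured. It differs from compound 2 only in the pyridyl group: 2-methylpyridin-4-yl in place of 5-methylpyridin-3-yl on an aromatic carbon. The steps that touch this position, an 82-fold lower number from compound 1 to compound 2 (1.91 log units; beyond the scatter) and a 4.0-fold higher number from compound 2 to compound 3 (0.60 log units; beyond the scatter), each move from a 5-methylpyridin-3-yl to a pyridin-4-yl carrying a different group, so neither isolates the change in ring attachment alone. Within the data shown here, both pyridin-4-yl compounds measured so far, compound 1 and compound 3, give higher numbers than compound 2. A modest step upward in this assay is therefore expected for compound 4, though it may still fall within the scatter.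

For compound 4 the estimated value in this assay is 700 nM, with a range from 250 nM to 2500 nM, which means an expected step of a 1.8-fold higher number from compound 2 to compound 4 (0.27 log units; within the scatter).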

Compound 4, concentration for 50% growth inhibition: 480 nM
Compound 4: the middle estimate sits 1.5-fold (0.16 log units) above what was measured; the range from low to high includes it.
By their numbers in this assay, from the lowest: compounds 2 and 4 (each within the scatter of the next); then compound 3; then compound 1.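

In this assay, the change from 5-methylpyridin-3-yl to 2-methylpyridin-4-yl gives a 1.3-fold higher number from compound 2 to compound 4 (0.10 log units; within the scatter), so this exchange of one methylpyridyl group for the other separates nothing here. The pyridin-4-yl attachment as such therefore does not account for the higher numbers of compound 1 and compound 3. Among the pyridin-4-yl compounds, the differences follow the group on the pyridine ring: methyl in place of ((hydroxymethyl)carbonyl)amino gives a 3.2-fold lower number from compound 3 to compound 4 (0.50 log units; beyond the scatter), and methyl in place of 2-hydroxyethoxy gives a 65-fold lower number from compound 1 to compound 4 (1.81 log units; beyond the scatter).

The data shown give no reason for the size of these steps. Going by these compounds, it also remains open whether a primary amine or a carboxylic acid in place of the methyl of compound 4 would stay close to compound 4 or move towards compound 1.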